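The compounds below may be only part of what the source reports. "The series", "measured", "known", "first", "only" and "open" are said of these compounds alone.

In a functional assay on HT-1080 cells (Homo sapiens) for antiproliferative activity, read by MTT assay, with a stated time of 72 h (on this read-out higher numbers stand for weaker inhibition and lower numbers for stronger inhibition), compound 1 (`CCOC(=O)c1cc(-c2cc(OC)c(OC)c(OC)c2)c(-c2ccc3ccccc3c2)s1`), an ethyl ester, gives 1150 nM and compound 2 (`COc1cc(-c2cc(C(=O)O)sc2-c2ccc3ccccc3c2)cc(OC)c1OC`), which carries a free carboxy group, gives 13400 nM as the higher of these two numbers. Compound 3 (`COc1cc(-c2ccsc2-c2ccc3ccccc3c2)cc(OC)c1OC`) has hydrogen in place of carboxy on an aromatic carbon and is still unmeasured. For the measured compounds named here, only one measured step bears on this, at the same group but through a different change: hydrogen in place of ethyl on an oxygen next to a carbonyl group gave a 12-fold higher number from compound 1 to compound 2 (1.07 log units; beyond the scatter) as a large step beyond the scatter. Going by the values given here, no measured compound lacks the group altogether, so this guide is loose. The free carboxy group goes with the higher number in this pair, so its removal is expected to lower the number. The expected change is an 8.9-fold lower number from compound 2 to compound 3 (0.95 log units; beyond the scatter) in this assay as a large step downward. For compound 3 the estimate is 1500 nM with an expected range of 250 nM to 8000 nM in repeated measurements.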

Compound 3, half-maximal inhibitory concentration: 5430 nM
For compound 3 the middle estimate is 3.6-fold (0.56 log units) below the measured one; measured number inside the range.
By their numbers in this assay, from the lowest: compound 1; then compound 3; then compound 2.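

In this assay, replacing the carboxy group next to the ring sulfur with hydrogen gives a 2.5-fold lower number from compound 2 to compound 3 (0.39 log units; beyond the scatter) as a modest step, so the loss of the ethyl group seen earlier is only partly recovered by removing the whole carboxy group. Replacing the ethoxycarbonyl group with hydrogen gives a 4.7-fold higher number from compound 1 to compound 3 (0.67 log units; beyond the scatter) in the same assay, which places the unsubstituted carbon between the two carbonyl-bearing compounds and shows that the direction of change at this position depends on which group is present: ethoxycarbonyl goes with a lower number than hydrogen, and carboxy with a higher one. Nothing available explains this order.

The compounds shown leave open whether a primary amide, a hydroxymethyl group or a longer chain on the ester oxygen would follow the ethyl ester or the free acid at this carbon. They also leave open whether this order would hold in cell lines other than HT-1080.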